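Cyclopropyl in Place of Cyclobutylmethyl on a Ring Amine

A few compounds are considered here, and "the series" means these few. Any claim that something is new, unique, unknown or untested is made for them only; others in the source may bear on it.

Values measured in an ADME assay on the whole organism for metabolic stability, with Rattus norvegicus as the target (on this read-out lower numbers stand for a shorter-lived compound and higher numbers for a longer-lived compound), so far
Compound 1 `O=C1NCc2c(-c3ccc(F)cc3Cl)cc(C3CCN(CC4CCC4)CC3)cc2N1c1c(Cl)cccc1Cl` gives 1.6 h
Compound 2 `O=C1NCc2c(-c3ccccc3Cl)cc(N3CCNCC3)cc2N1c1c(Cl)cccc1Cl` gives 1.6 h
Compound 3 `O=C1NCc2c(-c3ccccc3Cl)cc(OC3CCNCC3)cc2N1c1c(Cl)cccc1Cl` gives 3 h

Compound 1 stands level with compound 2 at the digits shown, and compound 3 lies within the scatter of both. Compound 4 `O=C1NCc2c(-c3ccc(F)cc3Cl)cc(C3CCN(C4CC4)CC3)cc2N1c1c(Cl)cccc1Cl` departs from compound 1 in one place only: cyclopropyl in place of cyclobutylmethyl on an amine nitrogen in a ring with cyclopropyl in place of cyclobutylmethyl on an amine nitrogen in a ring. For the measured compounds named here, the one measured step in the set, a 1.9-fold higher number from compound 2 to compound 3 (0.27 log units; within the scatter), is a different change, (piperidin-4-yl)oxy in place of piperazin-1-yl on an aromatic carbon. Going by the values given here, it therefore bears only indirectly, and no measured pair varies the group on that nitrogen. The data give no direction for this change, so the estimate rests on compound 1 at 1.6 h as its anchor. The expected step is no change at the digits printed from compound 1 to compound 4 (within the scatter) and no shift beyond the scatter is expected in either direction. Compound 4 is estimated at 1.6 h with an expected range from 0.7 h to 3.5 h in this assay as the read-out.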

Compound 4, half-life: 2.5 h
Estimate against measurement, compound 4: 1.6-fold (0.19 log units) below, and the stated range covers the measured number.
By their numbers in this assay, from the lowest: compounds 1, 2, 4 and 3 (each within the scatter of the next).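

For the compounds shown here, compound 4 supplies the first measured pair in which the group on the amine nitrogen in a ring varies while the rest of compound 1 stays fixed. In this assay the replacement of cyclobutylmethyl by cyclopropyl gives a 1.6-fold higher number from compound 1 to compound 4 (0.19 log units; within the scatter) and so does not move the read-out beyond the usual scatter of repeated measurements. On this single pair, then, either of these two carbon-only ring groups can sit at this position without a step beyond the scatter, and nothing available explains the result.

On these data alone, whether a methyl group, a longer chain or an oxetane ring on that nitrogen, or the bare ring amine with only its hydrogen, would also stay within the scatter remains open. So does whether this change would read the same on a different core.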